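Swapping amino for hydroxy on a weakly active core

This account rests on a few compounds, and the source may have more. Where it says the series, first, only, none or still open, it means among the compounds named here.

In a functional assay on L1210 cells (Mus musculus) for inhibition (a higher number here means a weaker inhibitor, a lower number a stronger inhibitor), compound 1 (`C=C1[C@@H](O)[C@H](n2cnc3c(Cl)nc(N)nc32)O[C@@H]1CO`) gives 441000 nM. Compound 2 (`C=C1[C@@H](O)[C@H](n2cnc3c(N)nc(N)nc32)O[C@@H]1CO`) reads > 200000 nM, which is a limit of the assay and not a number. Compound 3 (`C=C1[C@@H](O)[C@H](n2cnc3c(O)nc(N)nc32)O[C@@H]1CO`) carries hydroxy in place of amino on an aromatic carbon. Among the measured compounds shown here, only one measured step bears on this change, and its size cannot be read: a step that the limit leaves unreadable from compound 1 to compound 2. Since a step that the limit leaves unreadable from compound 1 to compound 2 gives no size to carry over, no clear move in either direction is expected. The expected change is a step that the limit leaves unreadable from compound 2 to compound 3. Compound 3 is estimated at 250000 nM, with an expected range from 60000 nM to 700000 nM.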

Compound 3, half-maximal inhibitory concentration: > 200000 nM
Compound 3 gave a limit, no number; the forecaster's own chance of this, stated with the estimate: 50%; the middle value does not contradict the limit.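

Compound 2 and compound 3 each give a limit and not a number, so no new step can be read among compound 1, compound 2 and compound 3. How far chloro, amino and hydroxy on this aromatic carbon truly differ stays open, with most values stopping at one mark: the limit of > 200000 nM in this assay, at which 2 of the 3 values shown sit.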